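The compounds below may be only part of what the source reports. "The series", "measured", "known", "first", "only" and "open" are said of these compounds alone.

Three compounds of this study share one core. Compound 1 `CCn1c(/C=C2/C(=O)Nc3ccc(Br)cc32)nc2ccccc21` has no reported result: in a functional assay on BT-549 cells (Homo sapiens) for cytotoxicity, read by MTT assay, with a stated time of 48 h (on this read-out lower numbers stand for stronger inhibition and higher numbers for weaker inhibition), compound 1 stands as "not determined" (no result reported). Compound 2 `Cn1c(/C=C2/C(=O)Nc3ccc(Br)cc32)nc2ccccc21` was tested in this assay, and for compound 2 this assay gives only a limit, > 50000 nM, not a number. Compound 3 `CC(C)n1c(/C=C2/C(=O)Nc3ccc(Cl)cc32)nc2ccccc21`, which differs from compound 2 in two places, is the only one of the three with a number: in this assay compound 3 gives 35100 nM. Among the measured compounds shown here, compound 2 therefore stands at the edge of what this assay can report, at the limit of > 50000 nM in this assay, at which 1 of the 3 values shown sits, while one further entry carries no number at all, so no pair of measured compounds differing in a single place is available to size any step.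

Compound 4 `Cn1c(/C=C2/C(=O)Nc3ccc(F)cc32)nc2ccccc21` is the compound not yet measured. It differs from compound 2 in one place: fluoro in place of bromo on an aromatic carbon. For the measured compounds named here, with no measured step to lean on, the step from compound 2 to compound 4 in this assay is expected to be small, within the usual scatter, in either direction, and compound 2 sits at a limit, so a limit for compound 4 remains likely. Compound 4 is accordingly estimated at 50000 nM, within 20000 nM to 120000 nM, an expected step of a number no higher from compound 2 to compound 4 (the limit leaves the size open).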

Compound 4, half-maximal inhibitory concentration: 26900 nM
Compound 4: middle estimate off by 1.9-fold (0.27 log units), on the high side, and the stated range covers the measured number.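

In this assay the exchange of bromo for fluoro on this aromatic carbon gives an at least 1.8-fold lower number from compound 2 to compound 4 (0.26 log units; that floor lies within the scatter), the first step among these compounds that can be sized at all. As far as these compounds go, compound 2 has only a limit, > 50000 nM, so this step is a floor and its full size remains unknown: the limit of > 50000 nM in this assay, at which 1 of the 4 values shown sits. What the result adds is that this position, para to a fused ring, can carry a group with which the compound gives a single number, with compound 4 at 26900 nM. The printed floor does not by itself establish a change beyond the scatter.

The compounds shown leave open how a nitrile, an amine or a carboxylic acid on this aromatic carbon would read in this assay, and so whether any group at this position gives a number clearly apart from that of compound 4. They also leave open whether a longer chain in place of the methyl of compound 4 would shift the number with fluoro held in place.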